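The compounds below may be only part of what the source reports. "The series", "measured", "known", "first", "only" and "open" are said of these compounds alone.

In an ADME assay on microsomes from liver (Mus musculus) for metabolic stability, read by LC-MS, using NADPH, with a stated time of 30 min, tested at 0.1 uM (a higher number here means that more of the compound is left, a lower number that less of the compound is left), compound 1 `CS(=O)(=O)Nc1ccc2nccc(-c3ccncc3)c2n1` gives 95%. Compound 2 `O=S(=O)(CCO)c1cccc(-c2ccc3nccc(-c4ccncc4)c3n2)c1` gives 52%, the lower of the two numbers, and its gap to compound 1 lies beyond the usual scatter. Compound 3 `CS(=O)(=O)Nc1cccc(-c2ccc3nccc(-c4ccncc4)c3n2)c1` has yet to be measured. It differs from compound 2 on an aromatic carbon of a six-membered aromatic ring of carbon only, meta to a large group, where methanesulfonamido stands in place of (2-hydroxyethyl)sulfonyl (methanesulfonamido in place of (2-hydroxyethyl)sulfonyl on an aromatic carbon). Compound 1 also carries a methanesulfonamido group and reaches 95% in this assay, which hints at a gain for compound 3. This hint is weak, as it rests on a single compound that differs from compound 3 in more than one place. The expected change in this assay is a moderate rise, a number 14 percentage points higher from compound 2 to compound 3 (beyond the scatter). For compound 3 the estimated value is 66%, with an expected range of 42% to 88%.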

Compound 3, percent of the compound remaining: 50%
Beside the measured number, compound 3's estimate is 16 percentage points above it, within the range that was stated.
By their numbers in this assay, from the lowest: compounds 3 and 2 (each within the scatter of the next); then compound 1.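

In this assay, replacing (2-hydroxyethyl)sulfonyl with methanesulfonamido, at a place that is an aromatic carbon of a six-membered aromatic ring of carbon only, meta to a large group, gives a number 2 percentage points lower from compound 2 to compound 3 (within the scatter) and so does not separate the two groups. At this position, going from 6 heavy atoms and 3 hydrogen-bond acceptors to 5 heavy atoms and 2 hydrogen-bond acceptors, with 1 hydrogen-bond donor on each side, leaves the percent remaining within the usual scatter. Nothing measured here explains why the two groups read alike.

Going by these compounds, whether a different group at this place, such as an amine, a carboxylic acid or a longer chain, would give a clearly different number stays open. Also open, on these data alone, is whether this exchange would read the same at another position on the ring.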